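This account rests on a few compounds, and the source may have more. Where it says the series, first, only, none or still open, it means among the compounds named here.

Compound 1 `COc1ccc(CN(C(=O)C2CC2)c2cc(OC)c(OC)c(OC)c2)cc1O` stands as the stronger of the two measured compounds: in a functional assay on MGC-803 cells (Homo sapiens) for inhibition, read by MTT assay, with a stated time of 48 h (on this read-out higher numbers stand for weaker inhibition and lower numbers for stronger inhibition), compound 1 gives 59 nM, while compound 2 `C/C=C/C(=O)N(Cc1ccc(OC)c(Cl)c1)c1cc(OC)c(OC)c(OC)c1` gives 7100 nM, a gap well beyond the scatter. Compound 2 differs from compound 1 in more than one place, so its weaker result cannot be tied to any single change. Compound 3 `COc1ccc(CN(C(=O)C(C)Br)c2cc(OC)c(OC)c(OC)c2)cc1O` keeps the core of compound 1 and changes only the group on the carbonyl carbon: 1-bromoethyl in place of cyclopropyl on a carbonyl carbon. For the measured compounds named here, with no measured step of this kind to lean on, a modest rise in the number is expected, a 2.5-fold higher number from compound 1 to compound 3 (0.41 log units; beyond the scatter), possibly within the scatter. Compound 3 is estimated at 150 nM, in the range 40 nM to 800 nM.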

Compound 3, half-maximal inhibitory concentration: 120 nM
Compound 3: the middle estimate sits 1.3-fold (0.10 log units) above what was measured; low and high end bracket the measured number.
By their numbers in this assay, from the lowest: compound 1; then compound 3; then compound 2.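

In this assay, the step of a 2.0-fold higher number from compound 1 to compound 3 (0.31 log units; beyond the scatter) shows that the cyclopropyl group on this carbonyl carbon can be replaced by 1-bromoethyl, which has no ring and carries a bromine, at a modest cost. Activity therefore does not depend entirely on having the three-membered ring at this position. No measurement shown here explains the size of this step.

The compounds shown cannot separate the loss of the ring from the arrival of the bromine. As far as these compounds go, how a plain ethyl group or an amine would behave on this carbonyl carbon remains open.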